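Sulfonate ester in place of the amine on the core

The compounds below may be only part of what the source reports. "The series", "measured", "known", "first", "only" and "open" are said of these compounds alone.

Working notes on a small set of analogues sharing one core, tested in a functional assay on MDA-MB-435 cells (Homo sapiens) for cytotoxicity, read by MTT assay, with a stated time of 72 h; on this read-out higher numbers stand for weaker inhibition and lower numbers for stronger inhibition. Compound 1 `C[C@@H](Nc1c(C(=O)NCc2ccc(F)cc2)nc(Br)c2cccnc12)c1ccccc1` gives only a limit in this assay, > 20000 nM. Compound 2 `NCCCNc1c(C(=O)NCc2ccc(F)cc2)ncc2cccnc12` gives 16000 nM in this assay, and compound 3 `N[C@H]1CC[C@H](Nc2c(C(=O)NCc3ccccc3)nc(Br)c3cccnc23)CC1` gives 7000 nM. Among the three values, compound 1 stands at the limit of > 20000 nM in this assay, at which 1 of the 3 values shown sits, and is therefore the one without a number; nothing more can be said of its place than that.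

Compound 4 `Cc1ccc(S(=O)(=O)Oc2c(C(=O)NCc3ccc(F)cc3)nc(Br)c3cccnc23)cc1` has not yet been measured in this assay. It differs from compound 1 by ((4-methylphenyl)sulfonyl)oxy in place of (1-phenylethyl)amino on an aromatic carbon. Among the measured compounds shown here, no pair of measured compounds differs in a single place, so no measured step gives the size of such a change, and the expectation rests on the weak numbers of the whole set. The step from compound 1 to compound 4 is expected to be a number no higher from compound 1 to compound 4 (the limit leaves the size open), which is to say none beyond the scatter. Compound 4 is expected to give about 20000 nM in this assay, within a range from 7000 nM to 60000 nM, and this assay may well again report only a limit for it.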

Compound 4, half-maximal inhibitory concentration: > 20000 nM
Compound 4: only a limit was reported; the forecaster's own chance of this, stated with the estimate: 55%; the middle value sits exactly at the limit.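

Compound 1 and compound 4 both stand at a limit and not at a number, so no step can be read between them: the limit of > 20000 nM in this assay, at which 2 of the 4 values shown sit.

The compounds shown leave open how far ((4-methylphenyl)sulfonyl)oxy in place of (1-phenylethyl)amino on an aromatic carbon shifts the value on the shared core.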